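Adding a second thiophene ring to a bicyclic amine

A few compounds are considered here, and "the series" means these few. Any claim that something is new, unique, unknown or untested is made for them only; others in the source may bear on it.

Compound 1 `CCCCc1ccsc1CN[C@@H]1C[C@H]2C[C@@H]([C@H]1C)C2(C)C` and compound 2 `C[C@H]1[C@H](NCc2cccs2)C[C@H]2C[C@@H]1C2(C)C` share a bicyclic amine core joined through a methylene to a thiophene ring. In an ADME assay on MDCK cells (Canis lupus familiaris) for cytotoxicity, read by microscopy, with a stated time of 48 h (on this read-out lower numbers stand for higher toxicity in this test and higher numbers for lower toxicity in this test), compound 1 gives 25000 nM, and compound 2 gives 25000 nM. Going by the values given here, the only step measured so far, no change at the digits printed from compound 1 to compound 2 (within the scatter), shows that removing the butyl chain from the thiophene carbon left the read-out unchanged. Compound 2 therefore stands level with compound 1 on the numbers seen.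

Compound 3 `C[C@H]1[C@H](NCc2sccc2-c2ccsc2)C[C@H]2C[C@@H]1C2(C)C` differs from compound 2 in one place: thiophen-3-yl in place of hydrogen on an aromatic carbon. The new group sits on the same ring carbon that carried the butyl chain in compound 1, so the step from compound 1 to compound 2 is the one that bears on this change, and it was flat. The step of no change at the digits printed from compound 2 to compound 3 (within the scatter) is accordingly expected to stay within the scatter, and compound 3 is estimated at 25000 nM, with a range from 8000 nM to 50000 nM.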

Compound 3, minimum cytotoxic concentration: 12500 nM
Beside the measured number, compound 3's estimate is 2.0-fold (0.30 log units) above it; low and high end bracket the measured number.
By their numbers in this assay, from the lowest: compounds 3, 1 and 2 (each within the scatter of the next).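

In this assay, thiophen-3-yl on this aromatic carbon gives a 2.0-fold lower number from compound 2 to compound 3 (0.30 log units; within the scatter), and the exchange of the butyl chain for the same group gives a 2.0-fold lower number from compound 1 to compound 3 (0.30 log units; within the scatter). This carbon has now carried hydrogen, a butyl chain and a whole aromatic ring, and compounds 1, 2 and 3 all remain within the scatter of one another, so the read-out does not separate these three groups. No supporting measurement is available to explain this flat result at this carbon.

The compounds shown leave open whether a different kind of group on this carbon, such as an amine or a carboxylic acid, would shift the number beyond the scatter. They also leave open whether a longer chain or a phenyl ring there would stay as flat as the butyl chain and thiophen-3-yl have.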